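Quinoxaline-diamine series: amino-linked replacement for aryl ether

The compounds below may be only part of what the source reports. "The series", "measured", "known", "first", "only" and "open" are said of these compounds alone.

Working notes on a small set read in a functional assay on TK-10 cells (Homo sapiens) for inhibition, read by sulforhodamine B assay, with a stated time of 48 h; on this read-out higher numbers stand for lower toxicity in this test and lower numbers for higher toxicity in this test. Compound 1 `Nc1cc(N)c2nc(-c3ccccc3)c(Oc3ccc(Cl)c(Cl)c3)nc2c1` carries the 3,4-dichlorophenoxy group on the core. In this assay compound 1 gives only a limit, < 100000 nM. Compound 2 `CCOC(=O)[C@H](CCC(=O)O)NC(=O)c1ccc(Sc2nc3cc(N)cc(N)c3nc2-c2ccccc2)cc1` likewise returns a limit in this assay, < 100000 nM. Compound 3 `COc1cc(CNc2nc3cc(N)cc(N)c3nc2-c2ccccc2)cc(OC)c1OC` sits at a different limit in this assay, < 50200 nM. No numbered value exists for any member, so compound 1 cannot be placed against the others beyond the observation that two of the three values share one limit of < 100000 nM in this assay, at which 2 of the 3 values shown sit, and the third a tighter one (the limit of < 50200 nM in this assay, at which 1 of the 3 values shown sits).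

Compound 4 `Nc1cc(N)c2nc(-c3ccccc3)c(NCc3ccc(F)cc3)nc2c1` is not yet measured. It differs from compound 1 by (4-fluorobenzyl)amino in place of 3,4-dichlorophenoxy on an aromatic carbon. Going by the values given here, no measured step between neighbouring compounds exists, so the size of the change in this assay is open; an estimated step that the limit leaves unreadable from compound 1 to compound 4 is taken as the working assumption, with no direction claimed beyond the scatter. For compound 4 the expected value in this assay is 30000 nM, with a range of 5000 nM to 100000 nM, and a further limit-only result is considered likely.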

Compound 4, concentration lethal to 50% of the cells: 53700 nM
The estimate for compound 4 lay 1.8-fold (0.25 log units) below the measured number, and the stated range covers the measured number.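

No step from compound 1 to compound 4 can be read, because compound 1 stands only as a limit: the limit of < 100000 nM in this assay, at which 2 of the 4 values shown sit.

The compounds shown leave open whether (4-fluorobenzyl)amino in place of 3,4-dichlorophenoxy on an aromatic carbon changes the read-out at all, and in which direction.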